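The compounds below may be only part of what the source reports. "The series", "measured", "known", "first", "only" and "open" are said of these compounds alone.

Measured so far:
compound 1 `COc1cc(C2CC(c3ccc([N+](=O)[O-])cc3)=NN2C(C)=O)ccc1OCc1cn(Cc2ccc([N+](=O)[O-])cc2)nn1` — 7%
compound 2 `COc1ccc(C2CC(c3ccc(OCc4cn(Cc5ccc([N+](=O)[O-])cc5)nn4)cc3)=NN2C(C)=O)cc1` — 15%
compound 3 `COc1ccc(C2CC(c3ccc(OCc4cn(Cc5ccc([N+](=O)[O-])cc5)nn4)cc3)=NN2C(C)=O)cc1OC` — 8%

In a functional assay on THP-1 cells (Homo sapiens) for inhibition, read by sulforhodamine B assay, tested at 10 uM (on this read-out higher numbers stand for more inhibition of growth at the one concentration tested and lower numbers for less inhibition of growth), compound 1 gives 7%, the lowest of the three numbers, but its gaps to compound 3 and to compound 2 both lie within the scatter, so the three measured compounds cannot be ordered. For the measured compounds named here, the only step measured within the set, a number 7 percentage points lower from compound 2 to compound 3 (within the scatter), concerns a methoxy in place of hydrogen on an aromatic carbon and lies within the scatter.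

Compound 4 `COc1cc(C2CC(c3cc(OC)c(OC)c(OC)c3)=NN2C(C)=O)ccc1OCc1cn(Cc2ccc([N+](=O)[O-])cc2)nn1` differs from compound 1 in one place: 3,4,5-trimethoxyphenyl in place of 4-nitrophenyl on a carbon with a double bond to nitrogen. Going by the values given here, no measured step concerns this replacement on the carbon with a double bond to nitrogen of the shared core. The one step shown is at a different place and was itself within the scatter. With all measured numbers close together and nothing bearing directly on the change, no step beyond the scatter is expected. The step of a number 3 percentage points higher from compound 1 to compound 4 (within the scatter) is the expected outcome. Compound 4 is estimated at 10%, with a range from 0% to 28%.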

Compound 4, percent growth inhibition at one concentration: 29%
Beside the measured number, compound 4's estimate is 19 percentage points below it; the measured number lies above the stated range.
By their numbers in this assay, from the lowest: compounds 1, 3 and 2 (each within the scatter of the next); then compound 4.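

In this assay the replacement of 4-nitrophenyl by 3,4,5-trimethoxyphenyl on the carbon with a double bond to nitrogen gives a number 22 percentage points higher from compound 1 to compound 4 (beyond the scatter) and is the only step shown that clears the scatter. For the compounds shown here, the group on this carbon can therefore move the read-out, which the one earlier step, a number 7 percentage points lower from compound 2 to compound 3 (within the scatter) at a different place, could not show. No supporting data bear on why this replacement raises the number.

Going by these compounds, with a single pair at this position, it remains open whether the step follows from the departure of the nitro group, the arrival of the methoxy groups, or both. On these data alone, it is also open how an amine or a carboxylic acid on this phenyl ring would compare, and whether the same replacement gives a similar step on the core of compound 2.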